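The source may report more compounds than this note shows. Statements on the series, on what has been measured and on what is new or still open speak of the compounds shown alone.

Two compounds sharing one core and differing in the length of their chain have been measured so far. In a functional assay on HCT-116 cells (Homo sapiens) for antiproliferative activity, read by MTT assay, with a stated time of 48 h (on this read-out lower numbers stand for stronger inhibition and higher numbers for weaker inhibition), compound 1 `CCCCC(CCO)n1cnc2c(OC)ncnc21` gives > 50000 nM, which is a limit of the assay and not a number. Compound 2 `CCCCCCC(CCO)n1cnc2c(OC)ncnc21` gives > 50000 nM, which is also a limit and not a number. Compound 2 therefore has no exact value, and it stands with compound 1 at the limit of > 50000 nM in this assay, at which 2 of the 2 values shown sit.

Compound 3 `CCCCCCCC(CCO)n1cnc2c(OC)ncnc21` differs from compound 2 by one small change: methyl in place of hydrogen on a saturated chain carbon, seven bonds along the chain from an aromatic nitrogen. In words, this is methyl in place of hydrogen on a saturated chain carbon, seven bonds along the chain from an aromatic nitrogen.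

Going by the values given here, only one measured step bears on this change, a step that the two limits leave unreadable from compound 1 to compound 2, so it offers no size or direction to carry forward. With nothing to point either way, the expectation is for no change beyond the usual scatter, and compound 3 will quite likely report only a limit again. The estimated result is a number no higher from compound 2 to compound 3 (the limit leaves the size open). The expected value for compound 3 is 50000 nM, with an estimated range from 20000 nM to 100000 nM.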

Compound 3, half-maximal inhibitory concentration: 15300 nM
Compound 3: middle estimate off by 3.3-fold (0.51 log units), on the high side; measured number below the stated range.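

In this assay, methyl in place of hydrogen on a saturated chain carbon, seven bonds along the chain from an aromatic nitrogen, produces an at least 3.2-fold lower number from compound 2 to compound 3 (0.51 log units; beyond the scatter), the first readable effect of chain length in this series. Measured against the shortest chain, the longest chain gives an at least 3.2-fold lower number from compound 1 to compound 3 (0.51 log units; beyond the scatter), while the step between the two shorter chains cannot be read. Activity therefore comes into measurable range only with the longest of the three chains, and compound 3 alone carries an exact number rather than a limit: the limit of > 50000 nM in this assay, at which 2 of the 3 values shown sit.

On these data alone, three compounds cannot show whether a still longer chain would keep lowering the number, level off or reverse the trend, so the best chain length remains unknown. As far as these compounds go, it is also open whether length alone matters at this position, or whether an amine or a carboxylic acid in place of the added methyl would give a similar result.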